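Aryl urea cyclohexyl ethers: cytotoxicity across the anilide ring

This account rests on a few compounds, and the source may have more. Where it says the series, first, only, none or still open, it means among the compounds named here.

Measured so far:
compound 1 `Cc1ccc(NC(=O)N[C@H]2CC[C@H](Oc3ccc(F)cc3)CC2)cc1`: > 20000 nM
compound 2 `O=C(Nc1cccc(F)c1)N[C@H]1CC[C@H](Oc2ccc(F)cc2)CC1`: 8300 nM

In a functional assay on CRL2813 cells (Homo sapiens) for cytotoxicity, read by sulforhodamine B assay, with a stated time of 5 days (a lower number here means a stronger inhibitor, a higher number a weaker inhibitor), compound 1 gives > 20000 nM, which is a limit of the assay (the limit of > 20000 nM in this assay, at which 1 of the 2 values shown sits). In this assay, among the measured compounds shown here, compound 2 gives 8300 nM, the only true number so far. For the measured compounds named here, the single measured step, an at least 2.4-fold lower number from compound 1 to compound 2 (0.38 log units; beyond the scatter), bears only loosely on the next change. Compound 3 `O=C(Nc1ccc(Br)cc1)N[C@H]1CC[C@H](Oc2ccc(F)cc2)CC1` carries 4-bromophenyl in place of 3-fluorophenyl on an amide-type nitrogen. Going by the values given here, with no measured step on the 4-bromophenyl group, compound 3 is expected near compound 2, the estimate being 9000 nM (range 2500 nM to 30000 nM), meaning an expected step of a 1.1-fold higher number from compound 2 to compound 3 (0.04 log units; within the scatter).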

Compound 3, half-maximal inhibitory concentration: > 20000 nM
Compound 3 gave a limit, no number (the forecaster's own chance of this, stated with the estimate: 30%); middle value at least 2.2-fold (0.34 log units) from the limit.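

In this assay, 4-bromophenyl in place of 3-fluorophenyl on the amide-type nitrogen gives an at least 2.4-fold higher number from compound 2 to compound 3 (0.38 log units; beyond the scatter), so this position does not accept every aryl change without loss. Compound 3, like compound 1, reads only as a limit, and among these three anilide rings only 3-fluorophenyl yields a true number: the limit of > 20000 nM in this assay, at which 2 of the 3 values shown sit. The step between compound 1 and compound 3 cannot be read, as both values are limits. Still open, going by these compounds, is whether the halogen or its place on the ring decides the outcome, and how an amine or a nitrile on this ring would read.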